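Working notes: the step from compound 3 to compound 4

This account rests on a few compounds, and the source may have more. Where it says the series, first, only, none or still open, it means among the compounds named here.

Compound 1 `COc1cc(OC)c(-c2coc3cc(OCC(=O)c4cccc(C(F)(F)F)c4)ccc3c2=O)cc1OC`: > 10000 nM, a limit
Compound 2 `COc1cc(OC)c(-c2coc3cc(OCc4ccc(F)cc4)ccc3c2=O)cc1OC`: 3200 nM
Compound 3 `COc1cc(OC)c(-c2coc3cc(OCc4ccccc4C(F)(F)F)ccc3c2=O)cc1OC`: > 10000 nM, a limit

All three were tested in a functional assay on U-251 cells (Homo sapiens) for antiproliferative activity, read by MTT assay, with a stated time of 24 h; a higher number here means a weaker inhibitor, a lower number a stronger inhibitor. Compound 3 is known only as a limit, > 10000 nM.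

Compound 4 `COc1cc(OC)c(-c2coc3cc(OCc4cccc(F)c4)ccc3c2=O)cc1OC` differs from it as follows: 3-fluorophenyl in place of 2-(trifluoromethyl)phenyl on a saturated chain carbon bound to an oxygen on an aromatic ring. In short, 2-(trifluoromethyl)benzyl gives way to 3-fluorobenzyl. The closest measured compound is compound 2, with 4-fluorophenyl in that place, at 3200 nM. For the measured compounds named here, the steps that bear on the change are an at least 3.1-fold higher number from compound 2 to compound 3 (0.49 log units; beyond the scatter) and an at least 3.1-fold lower number from compound 1 to compound 2 (0.49 log units; beyond the scatter). Going by the values given here, no measured compound carries 3-fluorophenyl, so a reversal of similar size is expected only tentatively, towards a lower number in this assay. The expected step is an at least 2.5-fold lower number from compound 3 to compound 4 (0.39 log units; beyond the scatter). For compound 4 the estimated value is 4000 nM, with an expected range of 1500 nM to 10000 nM.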

Compound 4, half-maximal inhibitory concentration: 3510 nM
Compound 4: the middle estimate sits 1.1-fold (0.06 log units) above what was measured; measured number inside the range.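

Working notes, this assay: on the saturated chain carbon bound to an oxygen on an aromatic ring, 3-fluorobenzyl gives a measured value where 2-(trifluoromethyl)benzyl gives only a limit (an at least 2.8-fold lower number from compound 3 to compound 4 (0.45 log units; beyond the scatter)). Exchanging 4-fluorophenyl for 3-fluorophenyl makes no readable difference (a 1.1-fold higher number from compound 2 to compound 4 (0.04 log units; within the scatter)), so among these two compounds the fluorine's ring position does not matter. Against the carbonyl-bearing side chain, the 3-fluorobenzyl group again gives the lower number (an at least 2.8-fold lower number from compound 1 to compound 4 (0.45 log units; beyond the scatter)).

From the compounds shown here alone, whether an amine or a carboxylic acid on this benzyl ring, or a longer chain at this place, would move the number stays open. The full size of the steps involving compound 1 and compound 3 also stays open, since each of these two compounds is known only as a limit: the limit of > 10000 nM in this assay, at which 2 of the 4 values shown sit.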